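This account rests on a few compounds, and the source may have more. Where it says the series, first, only, none or still open, it means among the compounds named here.

Compound 1, `CCC(C)C(NC(=O)n1nnc2ccccc21)C(=O)NCc1ccccc1`, gives 69200 nM in a functional assay on MCF7 cells (Homo sapiens) for inhibition; a higher number here means a weaker inhibitor, a lower number a stronger inhibitor.
Compound 2, `CCC(C)C(NC(=O)n1nnc2ccccc21)C(=O)NC(c1ccccc1)c1ccccc1`, reaches only > 100000 nM in this assay, which is a limit of the assay and not a number.
Compound 3, `O=C1NC(c2ccccc2)C(=O)N1Cc1ccccc1`, gives 3300 nM in this assay.

Compound 3 stands at the lowest of the two numbers; compound 1 sits at a markedly higher number, a gap beyond the scatter. Compound 2 sits at the limit (the limit of > 100000 nM in this assay, at which 1 of the 3 values shown sits). Compound 4, `CCC(C)C1NC(=O)N(Cc2ccccc2)C1=O`, has not yet been measured. It differs from compound 3 in one place: sec-butyl in place of phenyl on a saturated ring carbon. Going by the values given here, the only measured step, an at least 1.4-fold higher number from compound 1 to compound 2 (0.15 log units; that floor lies within the scatter), adds a phenyl on a chain carbon rather than exchanging one on the ring, and its floor lies within the scatter, so it bears on compound 4 only loosely. Compound 1, which carries the same sec-butyl on a different core, gives a high number, while compound 3 with phenyl on the ring gives the lowest. On that basis compound 4 is expected to give a higher number than compound 3, a step of a 4.5-fold higher number from compound 3 to compound 4 (0.66 log units; beyond the scatter). The estimate for compound 4 is 15000 nM, between 4000 nM and 60000 nM.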

Compound 4, half-maximal inhibitory concentration: 29500 nM
Compound 4: the middle estimate sits 2.0-fold (0.29 log units) below what was measured; the range from low to high includes it.
By their numbers in this assay, from the lowest: compound 3; then compound 4; then compound 1. At a limit, above all of these: compound 2.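

Exchanging phenyl for sec-butyl on the saturated ring carbon gives an 8.9-fold higher number from compound 3 to compound 4 (0.95 log units; beyond the scatter) in this assay. Going by these compounds alone, this is the first direct reading at this position, since the only earlier step concerned a chain carbon and its floor lay within the scatter; here the group on the ring carbon clearly shifts the number, and of the two groups, phenyl goes with the lower one. Nothing shown accounts for the size of this step.

Within the data shown here, with only two groups at this position, the compounds leave open whether the lower number requires an aromatic ring or any ring at all, which cyclohexyl on the same carbon would help to separate. They also leave open how a shorter chain such as methyl, or an amine or a carboxylic acid on the phenyl, would read.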